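This account rests on a few compounds, and the source may have more. Where it says the series, first, only, none or still open, it means among the compounds named here.

Measured compounds:
compound 1, `O=C(Nc1cccc(-n2cc(-c3ccncc3)c(-c3cc(O)cc(Cl)c3)n2)c1)Nc1ccc(Cl)c(Cl)c1`, in a functional assay on MDA-MB-231 cells (Homo sapiens) for inhibition, read by sulforhodamine B assay, with a stated time of 48 h, tested at 100 uM (a higher number here means a weaker effect of the compound at the concentration tested, a lower number a stronger effect), gives -24%
compound 2, `COc1cc(Cl)cc(-c2nn(-c3cccc(NC(=O)Nc4cc(C(F)(F)F)cc(C(F)(F)F)c4)c3)cc2-c2ccncc2)c1`, in this assay gives -70%

Within the data shown here, of the two measured compounds, compound 2 has the lower of the two numbers in this assay; the only neighbour, compound 1, sits higher by a margin beyond the usual scatter, so compound 2 shows the stronger effect of the pair. Compound 3, `COc1cc(Cl)cc(-c2nn(-c3cccc(NC(=O)Nc4cccc(C(F)(F)F)c4)c3)cc2-c2ccncc2)c1`, has not yet been measured. It differs from compound 2 in one place: hydrogen in place of trifluoromethyl on an aromatic carbon. Among the measured compounds shown here, nothing among the measured compounds isolates this change, so its effect in this assay is not known from the data. Compound 3 is expected to give a somewhat higher number than compound 2, that is a weaker effect, by a step estimated as a number 20 percentage points higher from compound 2 to compound 3 (beyond the scatter), with much uncertainty in either direction. For compound 3 the estimated value in this assay is -50%, within a range from -80% to -15%.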

Compound 3, a percentage reported as activity, at one concentration (the size of the read-out at that concentration, not a potency): -43%
For compound 3 the middle estimate is 7 percentage points below the measured one; the range from low to high includes it.
By their numbers in this assay, from the lowest: compound 2; then compound 3; then compound 1.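

In this assay, this aromatic carbon responds to the change: hydrogen in place of trifluoromethyl gives a number 27 percentage points higher from compound 2 to compound 3 (beyond the scatter) and thus a weaker effect at the concentration tested. The effect does not vanish with this change, since compound 3, which keeps the other trifluoromethyl group on that ring, still gives -43% and so shows that this trifluoromethyl group is not needed for a measurable read-out. Nothing in the data shown accounts for the size of this step.

As far as these compounds go, how a nitrile, an amine or a carboxylic acid on this carbon would compare with hydrogen and trifluoromethyl stays open. So does the question of whether replacing the remaining trifluoromethyl group with hydrogen would bring a further step of similar size.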